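The compounds below may be only part of what the source reports. "The series", "measured", "known", "first", "only" and "open" are said of these compounds alone.

In a functional assay (brain) for inhibition, with Rattus norvegicus as the target; a lower number here means a stronger inhibitor, a higher number a weaker inhibitor:
- compound 1, `Cc1c(C)c2c(c(C)c1O)CCC(C)(C(=O)N1CCCC1)O2`: 10000 nM
- compound 2, `Cc1c(C)c2c(c(C)c1O)CCC(C)(C(=O)NCCCc1ccccc1)O2`: 1000 nM

Compound 2 holds the lower of the two numbers in this assay; its nearest neighbour, compound 1, gives 10000 nM, a gap beyond the scatter of this assay. No single-change pairing between the two is available, so only the two values themselves speak.

Compound 3, `Cc1c(C)c2c(c(C)c1O)CCC(C)(C(=O)NCCN(C)C)O2`, is reached from compound 2 by one change: dimethylamino in place of benzyl on a saturated chain carbon, two bonds along the chain from an amide-type nitrogen. The aromatic tail of compound 2 is thus gone, and compound 1, the only other amide on this core, carries no such tail and is the weaker of the two. On that basis a weakening is expected, of moderate size, beyond the scatter, with a 4.0-fold higher number from compound 2 to compound 3 (0.60 log units; beyond the scatter) as the expected step. For compound 3 in this assay the estimate is 4000 nM, with a range from 1000 nM to 15000 nM.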

Compound 3, half-maximal inhibitory concentration: 8700 nM
Beside the measured number, compound 3's estimate is 2.2-fold (0.34 log units) below it; measured number inside the range.
By their numbers in this assay, from the lowest: compound 2; then compounds 3 and 1 (each within the scatter of the next).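

In this assay, dimethylamino in place of benzyl on a saturated chain carbon, two bonds along the chain from an amide-type nitrogen, gives an 8.7-fold higher number from compound 2 to compound 3 (0.94 log units; beyond the scatter), so within this pair the lower number goes with the 3-phenylpropyl tail and not with the 2-(dimethylamino)ethyl tail. With (2-(dimethylamino)ethyl)amino in place of pyrrolidin-1-yl on a carbonyl carbon, the comparison gives a 1.1-fold lower number from compound 1 to compound 3 (0.06 log units; within the scatter), so this assay does not separate these two amide groups. Nothing available here accounts for either step.

Open, as far as these compounds go, is whether the phenyl ring itself or the length of the chain carries the difference, a question that a 3-cyclohexylpropyl amide or a shorter phenethyl amide would address. Also open, from the compounds shown here alone, is whether a longer amine chain, such as 3-(dimethylamino)propyl, would behave like the 2-(dimethylamino)ethyl tail.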